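The source may report more compounds than this note shows. Statements on the series, on what has been measured and on what is new or still open speak of the compounds shown alone.

Compound 1 `CCN1CCCC(n2cc(S(=O)(=O)c3ccccc3)c3ccccc32)C1` gives 7.3 nM in an assay on HeLa cells for displacement of a labelled ligand from 5-hydroxytryptamine receptor 6 (Homo sapiens), with a stated time of 2 h; on this read-out higher numbers stand for weaker inhibition and lower numbers for stronger inhibition. Among the three measured compounds it holds the second highest number. Compound 2 `O=S(=O)(c1cccc(F)c1)c1cn(C2CCCNC2)c2ccccc12` gives 6 nM in this assay, a value within the scatter of compound 1. Compound 3 `CCN1CCCC(n2cc(S(=O)(=O)c3cccc(F)c3)c3cc(OC)ccc32)C1` gives 16 nM, a higher number than compound 1 and beyond the scatter.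

The next compound, compound 4 `O=S(=O)(c1ccccc1)c1cn(C2CCNC2)c2ccccc12`, arises from compound 1 by one change: pyrrolidin-3-yl in place of 1-ethylpiperidin-3-yl on an aromatic nitrogen. Going by the values given here, no measured pair shows this change, so its effect is unknown. Among the compounds with values here, the only guide is that compound 2, which also carries a ring amine bearing a hydrogen, gives 6 nM, close to compound 1. The expected step is a 1.6-fold higher number from compound 1 to compound 4 (0.22 log units; within the scatter), small and of uncertain direction. Compound 4 is therefore expected to give about 12 nM, in a range from 4 nM to 40 nM.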

Compound 4, inhibition constant: 5 nM
For compound 4 the middle estimate is 2.4-fold (0.38 log units) above the measured one; the measured number falls inside the stated range.
By their numbers in this assay, from the lowest: compounds 4, 2 and 1 (each within the scatter of the next); then compound 3.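

In this assay the step is a 1.5-fold lower number from compound 1 to compound 4 (0.16 log units; within the scatter), so on this aromatic nitrogen, pyrrolidin-3-yl, a smaller ring with a hydrogen-bond donor, can replace 1-ethylpiperidin-3-yl without a change beyond the scatter. No measurement shown explains why the number holds. Ring size and the ethyl group changed together, so their separate effects remain unknown. As far as these compounds go, whether 1-ethylpyrrolidin-3-yl or an open-chain 2-aminoethyl group would behave the same way also remains open.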